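A few compounds are considered here, and "the series" means these few. Any claim that something is new, unique, unknown or untested is made for them only; others in the source may bear on it.

Measured so far:
Compound 1, `C=CCN(CC=C)c1nc(C)nc2c(-c3c(C)cc(OC)cc3OC)c(C)nn12`, in an assay on cell membranes for displacement of a labelled ligand from corticotropin-releasing factor receptor 1 (Rattus norvegicus) (on this read-out lower numbers stand for stronger inhibition and higher numbers for weaker inhibition), gives 1 nM.
Compound 3, `CCN(CC)c1nc(C)nc2c(-c3cc(F)c(OC)cc3Cl)c(C)nn12`, in this assay gives 1.64 nM.
Compound 2, `COc1ccc(-c2c(C)nn3c(NC4CCC4)nc(C)nc23)c(C)c1`, in this assay gives 24.6 nM.

Of the three values in this assay, compound 1 carries the lowest number, but its distance from compound 3 lies within the usual scatter of repeated measurements, so the two cannot be told apart on this evidence. Compound 2 stands clearly apart with a higher number, beyond the scatter, and is the only one of the three to carry a cyclobutylamino group rather than a dialkylamino group on its core.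

Compound 4, `CCC1CCCCN1c1nc(C)nc2c(-c3c(C)cc(OC)cc3OC)c(C)nn12`, has not yet been measured. It keeps the core and the aromatic ring of compound 1 and differs in one place: 2-ethylpiperidin-1-yl in place of diallylamino on an aromatic carbon. The group leaving is an open chain with two double bonds; the group entering is a six-membered ring with one nitrogen and an ethyl branch. For the measured compounds named here, compound 3 shows that a different pair of saturated chains on the same nitrogen still gives a low number, yet no measured pair shows a ring in this position.

The step of a 3.0-fold higher number from compound 1 to compound 4 (0.48 log units; beyond the scatter) is expected to be small, toward a somewhat higher number, possibly within the scatter. Compound 4 is estimated at 3 nM, with a likely range from 0.8 nM to 12 nM.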

Compound 4, half-maximal inhibitory concentration: 3.26 nM
For compound 4 the middle estimate is 1.1-fold (0.04 log units) below the measured one; measured number inside the range.
By their numbers in this assay, from the lowest: compounds 1, 3 and 4 (each within the scatter of the next, the first and the last beyond it); then compound 2.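

In this assay, for the compounds shown here, this is the first pair of compounds to show what happens at this position when an open chain gives way to a ring: a 3.3-fold higher number from compound 1 to compound 4 (0.51 log units; beyond the scatter) comes with 2-ethylpiperidin-1-yl in place of diallylamino. The step lies beyond the scatter but is modest, and compound 4 at 3.26 nM still sits in the low range of the numbers seen so far, so a six-membered non-aromatic ring with an ethyl branch can stand on this aromatic carbon between two ring nitrogen atoms without a large change in the number. Nothing measured here gives a reason for the size of this step.

From the compounds shown here alone, what the ethyl branch contributes on its own stays open: an unbranched piperidin-1-yl would separate the effect of the branch from that of the ring, and morpholin-4-yl, a six-membered ring that also holds an oxygen, would show whether the ring tolerates a second hetero atom. Going by these compounds, it is also open whether a ring in this position would give a similar step alongside the other aromatic rings seen in compound 2 and compound 3.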